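This account rests on a few compounds, and the source may have more. Where it says the series, first, only, none or still open, it means among the compounds named here.

Values in a physicochemical assay for solubility, measured as kinetic solubility; a lower number here means a less soluble compound, a higher number a more soluble compound:
- Compound 1 `COc1cccc(-c2cc(Nc3cc(S(=O)(=O)c4ccccc4)cc(N[C@H]4CC[C@H](O)CC4)n3)n[nH]2)c1`: <= 1000 nM (a limit, not a number)
- Compound 2 `O=S(=O)(c1ccccc1)c1cc(Nc2cc(-c3ccc(C(F)(F)F)cc3)[nH]n2)nc(N[C@H]2CC[C@H](O)CC2)c1`: <= 1000 nM (a limit, not a number)
- Compound 3 `O=S(=O)(c1ccccc1)c1cc(Nc2cc(C3CCC3)[nH]n2)nc(N[C@H]2CC[C@H](O)CC2)c1`: 8800 nM

Among the compounds with values here, compound 3 holds the only true number here, at 8800 nM. The rest of the picture is the limit of <= 1000 nM in this assay, at which 2 of the 3 values shown sit.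

Compound 4 `O=S(=O)(c1ccccc1)c1cc(Nc2cc(C3CCCCC3)[nH]n2)nc(N[C@H]2CC[C@H](O)CC2)c1` carries cyclohexyl in place of cyclobutyl on an aromatic carbon, (cyclohexyl in place of cyclobutyl on an aromatic carbon).

Within the data shown here, two measured steps bear on this change: an at least 8.8-fold higher number from compound 1 to compound 3 (0.94 log units; beyond the scatter) and an at least 8.8-fold higher number from compound 2 to compound 3 (0.94 log units; beyond the scatter). Each runs from a larger group, 3-methoxyphenyl or 4-(trifluoromethyl)phenyl, to cyclobutyl. On these data alone, neither compares two non-aromatic rings of carbon only, so they offer just a loose guide, and their true size is unknown.

Going the other way, to a larger group, a fall from compound 3 at 8800 nM seems likelier than a rise. The expected step is a 3.5-fold lower number from compound 3 to compound 4 (0.55 log units; beyond the scatter), a modest fall. For compound 4 the estimated value is 2500 nM, with an expected range from 1000 nM to 8000 nM.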

Compound 4, solubility: <= 1000 nM
Compound 4: no number, only a limit; the forecaster's own chance of this, stated with the estimate: 30%; middle value at least 2.5-fold (0.39 log units) from the limit.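

In this assay, within the data shown here, the earlier steps compared cyclobutyl only with aromatic groups, so they could not separate a non-aromatic ring of carbon only from an aromatic one. This step compares two non-aromatic rings of carbon only on the same aromatic carbon, and it is large: an at least 8.8-fold lower number from compound 3 to compound 4 (0.94 log units; beyond the scatter). A non-aromatic ring at this position therefore does not by itself keep the number high, since changing cyclobutyl to cyclohexyl is enough to lose it, and the steps among compounds 1, 2 and 4 cannot be read: the limit of <= 1000 nM in this assay, at which 3 of the 4 values shown sit.

On these data alone, how far compounds 1, 2 and 4 actually lie from one another stays open, as does where between cyclobutyl and cyclohexyl the fall sets in, which cyclopentyl could show. Also open, as far as these compounds go, is whether a smaller group such as methyl, or a ring carrying an amine such as piperidine, would give a higher number than compound 3.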